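Butoxy to benzyl at the anilino ring of the amidoxime series

This account rests on a few compounds, and the source may have more. Where it says the series, first, only, none or still open, it means among the compounds named here.

Compound 1 `O/N=C(/Nc1cccc(Br)c1)c1ccc2occc2c1` gives 440 nM in an assay on isolated protein for inhibition of Indoleamine 2,3-dioxygenase 1 (Homo sapiens), read by spectrophotometry; a higher number here means a weaker inhibitor, a lower number a stronger inhibitor. Compound 2 `O/N=C(/Nc1cccc(C(F)(F)F)c1)c1ccc2occc2c1` gives 1200 nM in this assay, and the step of a 2.7-fold higher number from compound 1 to compound 2 (0.44 log units; beyond the scatter) is modest. Compound 3 `CCCCOc1cccc(N/C(=N/O)c2ccc3occc3c2)c1` reaches only the limit of this assay, reported as > 30000 nM; this is one of the values that sit at the limit of > 30000 nM in this assay, at which 1 of the 3 values shown sits, so compound 3 stands as the weakest of the three measured compounds. The steps of an at least 68-fold higher number from compound 1 to compound 3 (1.83 log units; beyond the scatter) and an at least 25-fold higher number from compound 2 to compound 3 (1.39 log units; beyond the scatter) are both large, and both are bounded by the limit rather than fixed.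

Compound 4 `O/N=C(/Nc1cccc(Cc2ccccc2)c1)c1ccc2occc2c1` differs from compound 3 by benzyl in place of butoxy on an aromatic carbon. Going by the values given here, no measured step introduces a benzyl group, so only the two steps into compound 3 bear on this change, and they show that replacing the butoxy group by either of the two measured alternatives lowers the number by a large margin. Benzyl carries no hydrogen-bond acceptor where butoxy carried one, and adds a second aromatic ring at the same place. An improvement over compound 3 in this assay is therefore expected, though its size cannot be fixed from the measured steps. The expected step is an at least 5.0-fold lower number from compound 3 to compound 4 (0.69 log units; beyond the scatter). For compound 4 the estimate in this assay is 6000 nM, within a range from 1200 nM to 30000 nM.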

Compound 4, half-maximal inhibitory concentration: > 30000 nM
Compound 4 ended at the assay's limit; the forecaster's own chance of this, stated with the estimate: 25%; middle value at least 5.0-fold (0.69 log units) away from the limit.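

In this assay, benzyl in place of trifluoromethyl gives an at least 25-fold higher number from compound 2 to compound 4 (1.39 log units; beyond the scatter) and benzyl in place of bromo gives an at least 68-fold higher number from compound 1 to compound 4 (1.83 log units; beyond the scatter), so the large loss seen with butoxy at this place is not confined to butoxy. It holds for a group with 0 hydrogen-bond acceptors and a six-membered aromatic ring as well as for butoxy with 1 hydrogen-bond acceptor and no ring, so the oxygen of butoxy is not required for the loss. Compound 3 and compound 4 cannot be ordered, and the step between them cannot be read, because both values are limits of the assay: the limit of > 30000 nM in this assay, at which 2 of the 4 values shown sit.

Going by these compounds, whether a shorter chain such as methoxy or ethyl, or an amine or a carboxylic acid, on this aromatic carbon gives a value nearer to those of the bromo and trifluoromethyl compounds stays open. On these data alone, how far compound 3 and compound 4 lie past the limit also stays open, and with it whether benzyl and butoxy differ at all.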